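The source may hold more compounds than are shown below. What is called first, only, known or untested is meant among the compounds shown, and "the series" means these compounds.

Measured compounds:

Compound 1 `O=c1cc(-n2cc(COc3ccc(C(F)(F)F)cc3)nn2)c2cc(Br)ccc2o1`: 3090 nM
Compound 2 `O=c1cc(-n2cc(COc3ccc(F)cc3)nn2)c2cc(Br)ccc2o1`: 1770 nM

Both numbers come from a functional assay on SW480 cells (Homo sapiens) for antiproliferative activity, read by MTT assay, with a stated time of 48 h; on this read-out lower numbers stand for stronger inhibition and higher numbers for weaker inhibition. Compound 2 and compound 1 lie within the usual scatter of each other, as the step of a 1.7-fold lower number from compound 1 to compound 2 (0.24 log units; within the scatter) shows, so no order between them can be claimed. Compound 3 `COC(=O)c1ccc(OCc2cn(-c3cc(=O)oc4ccc(Br)cc34)nn2)cc1` differs from compound 2 in one place: methoxycarbonyl in place of fluoro on an aromatic carbon. Within the data shown here, the only measured step that bears on this change is the one from compound 1 to compound 2, which also swapped the group at this same place and stayed within the scatter. Among the measured compounds shown here, no measured compound carries a methoxycarbonyl group, so the effect of this larger group is not known from the data. The expected step of a 1.1-fold higher number from compound 2 to compound 3 (0.05 log units; within the scatter) is therefore small, with no clear direction beyond the scatter. Compound 3 is estimated to give 2000 nM in this assay, with a range from 800 nM to 5000 nM.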

Compound 3, half-maximal inhibitory concentration: 3620 nM
The estimate for compound 3 lay 1.8-fold (0.26 log units) below the measured number, and the stated range covers the measured number.
By their numbers in this assay, from the lowest: compounds 2, 1 and 3 (each within the scatter of the next, the first and the last beyond it).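

In this assay, among these compounds, the change to methoxycarbonyl in place of fluoro gives a 2.0-fold higher number from compound 2 to compound 3 (0.31 log units; beyond the scatter) and is the first change at this position to pass the scatter, though only modestly. Methoxycarbonyl in place of trifluoromethyl gives a 1.2-fold higher number from compound 1 to compound 3 (0.07 log units; within the scatter) and so allows no order between those two compounds. The three groups on this aromatic carbon therefore span a narrow range of numbers, and only fluoro and methoxycarbonyl can be told apart. No measurement shown here explains the difference between them. The compounds shown leave open whether an amine, a carboxylic acid or a longer chain at this place would move the number further, and whether a change elsewhere on the shared core would have a larger effect.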